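Nitro for Chloro: Estimating Compound 3

The source may report more compounds than this note shows. Statements on the series, on what has been measured and on what is new or still open speak of the compounds shown alone.

Compound 1, `O=S(=O)(Nc1ccc2oc(-c3ccc(NS(=O)(=O)c4cccc5nonc45)cc3)nc2c1)c1ccc(Cl)s1`: in an assay for inhibition of HSP60/HSP10 (Homo sapiens), with a stated time of 60 min (a lower number here means a stronger inhibitor, a higher number a weaker inhibitor), compound 1 gives 11000 nM.
Compound 2, `O=S(=O)(Nc1ccc2oc(-c3ccc(NS(=O)(=O)c4ccc(Cl)s4)cc3)nc2c1)c1ccc(Cl)c(Cl)c1`: in this assay compound 2 gives 4700 nM.

Compound 2 holds the lower of the two numbers in this assay, and compound 1 stands beyond the scatter above it. Compound 3, `O=[N+]([O-])c1cc(S(=O)(=O)Nc2ccc3oc(-c4ccc(NS(=O)(=O)c5ccc(Cl)s5)cc4)nc3c2)ccc1Cl`, differs from compound 2 by nitro in place of chloro on an aromatic carbon. Going by the values given here, no measured pair here carries this change, so nothing in the data sets its size. The expected step is a 1.0-fold lower number from compound 2 to compound 3 (0.02 log units; within the scatter), within the scatter and in no firm direction. Compound 3 is estimated at 4500 nM in this assay, with a range from 1500 nM to 13000 nM.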

Compound 3, half-maximal inhibitory concentration: 1000 nM
The estimate for compound 3 lay 4.5-fold (0.65 log units) above the measured number, and the stated range ends above it.
By their numbers in this assay, from the lowest: compound 3; then compound 2; then compound 1.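

Nitro in place of chloro, ortho to a chloro group on the six-membered aromatic ring, gives a 4.7-fold lower number from compound 2 to compound 3 (0.67 log units; beyond the scatter) in this assay and lies beyond the scatter. This shows that the number in this assay responds to the group at this position, and that 4-chloro-3-nitrophenyl carries the lower number of this pair. Nothing at hand accounts for the size of this step. Going by these compounds, whether an amine, a nitrile or a carboxylic acid at this position would lower the number further remains open. So does whether nitro for chloro would give a similar step elsewhere on the shared core.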